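The source may hold more compounds than are shown below. What is called first, only, known or untested is meant among the compounds shown, and "the series" means these compounds.

The series shares one core, seen in compound 1, `COC(=O)c1cccc(C(=O)N2CCC(N(C3CC3)S(=O)(=O)c3cccc(C(F)(F)F)c3)CC2)c1`, compound 2, `O=C(c1ccccc1)N1CCC(N(C2CC2)S(=O)(=O)c2cccc(C(F)(F)F)c2)CC1`, compound 3, `O=C(c1cccc(OC(F)(F)F)c1)N1CCC(N(C2CC2)S(=O)(=O)c2cccc(C(F)(F)F)c2)CC1`, and compound 4, `CN(C)c1cccc(C(=O)N2CCC(N(C3CC3)S(=O)(=O)c3cccc(C(F)(F)F)c3)CC2)c1`. In an assay on cells for inhibition of Voltage-dependent L-type calcium channel subunit alpha-1C (Homo sapiens), read by FLIPR and calcium flux, tested at 3 uM (on this read-out lower numbers stand for a weaker effect and higher numbers for a stronger effect at the one concentration tested), compound 1 gives "not determined" (no result reported), and compound 2 gives "not determined" (no result reported). Within the data shown here, compound 3 is therefore the only member with a number in this assay: compound 3 gives 78%, and nothing else in the set lets one judge whether that value is high or low for this core. Compound 4 differs from compound 3 in one place, (dimethylamino in place of trifluoromethoxy on an aromatic carbon). Among the measured compounds shown here, no pair of measured compounds shows what such a change does here, so the size of any step has to be guessed from the single value of compound 3 alone. The expectation is a step from compound 3 to compound 4 of moderate size, somewhat downward, a number 18 percentage points lower from compound 3 to compound 4 (beyond the scatter), though a step within the scatter cannot be excluded. Compound 4 is thus estimated at 60%, with a range from 30% to 85%.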

Compound 4, a percentage reported as inhibition, at one concentration (the size of the read-out at that concentration, not a potency): 63%
For compound 4 the middle estimate is 3 percentage points below the measured one; low and high end bracket the measured number.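

In this assay, among these compounds, placing dimethylamino instead of trifluoromethoxy on this aromatic carbon gives a number 15 percentage points lower from compound 3 to compound 4 (beyond the scatter) and thus the first readable step. The position therefore responds to the group it carries, although the swap does not abolish the effect at the one concentration tested, as compound 4 still gives 63% at that concentration. No measurement at hand accounts for the size or direction of this step.

Steps involving compound 1 and compound 2 cannot be read, so it remains unknown how either substituent compares with the unsubstituted benzoyl compound or the methyl ester. The compounds shown also leave open how a primary amine, a methoxy group or a chlorine atom would behave on the same carbon.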